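The compounds below may be only part of what the source reports. "The series", "measured", "known", "first", "only" and "open" are said of these compounds alone.

Compound 1, `CCN1CCN(CCC(=O)Nc2nc3c(C)cccc3s2)CC1`, in an assay on membranes from brain for displacement of a labelled ligand from Sigma non-opioid intracellular receptor 1 (Cavia porcellus), read by scintillation counting, with a stated time of 120 min (a higher number here means a weaker inhibitor, a lower number a stronger inhibitor), gives 543 nM. Compound 2, `CCCCCCN1CCN(CCC(=O)Nc2nc3c(C)cccc3s2)CC1`, in this assay gives 238 nM.

Compound 2 stands at the lower of the two numbers. Among the compounds with values here, the only measured step is a 2.3-fold lower number from compound 1 to compound 2 (0.36 log units; beyond the scatter), which lengthened the chain on the ring nitrogen.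

Compound 3 is `Cc1cccc2sc(NC(=O)CCN3CCN(C4CCN(C)CC4)CC3)nc12`. Its change from compound 2 is 1-methylpiperidin-4-yl in place of hexyl on an amine nitrogen in a ring. Within the data shown here, no measured step bears directly on this swap of the whole chain for a ring; the one step suggests only that a long chain helps. Compound 3 is therefore expected to give a higher number, a step of a 2.5-fold higher number from compound 2 to compound 3 (0.40 log units; beyond the scatter), estimated at 600 nM within 150 nM to 2500 nM.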

Compound 3, inhibition constant: 6000 nM
The estimate for compound 3 lay 10-fold (1.00 log units) below the measured number; measured number outside the range, above it.
By their numbers in this assay, from the lowest: compound 2; then compound 1; then compound 3.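

On the ring nitrogen, size alone does not set the number in this assay: hexyl has 6 heavy atoms and 1-methylpiperidin-4-yl has 7, yet the swap gives a 25-fold higher number from compound 2 to compound 3 (1.40 log units; beyond the scatter). The ring also falls behind the much shorter ethyl chain, with an 11-fold higher number from compound 1 to compound 3 (1.04 log units; beyond the scatter), so both chains shown here are better tolerated at this position than this ring. No available evidence explains the loss.

From the compounds shown here alone, whether the ring or its added nitrogen matters remains open; a cyclohexyl group at this position would help separate the two.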